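The source may report more compounds than this note shows. Statements on the series, on what has been measured and on what is new or still open speak of the compounds shown alone.

Compound 1 `CCCCCCCCCCCCCCCCc1nc(N2CCC2)c(C)c(C)c1O` — in a functional assay on cells (Lymphocyte, Homo sapiens) for inhibition, read by flow cytometry, using a membrane potential dye, with a stated time of 16 h, tested at 250 nM (a lower number here means a weaker effect, a higher number a stronger effect of the compound at the concentration tested), compound 1 gives 68%.
Compound 2 `CCCCCCCCCCc1nc(N(C)C)c(C)c(C)c1O` — in this assay compound 2 gives 82%.

For the measured compounds named here, on these two numbers compound 2 stands highest; its only neighbour, compound 1, sits lower by a gap beyond the usual scatter, though the two differ in two places, so that gap alone tells nothing about either change on its own. Compound 3 `CCCCCCCCCCCCCCCCc1nc(N(C)C)c(C)c(C)c1O` has not yet been measured in this assay. It differs from compound 2 by hexyl in place of hydrogen on a saturated chain carbon, ten or more bonds along the chain from an aromatic carbon. Going by the values given here, no measured pair isolates this change. A small step, downward if anything, is expected, a number 7 percentage points lower from compound 2 to compound 3 (within the scatter). Compound 3 is therefore estimated at 75%, within 58% to 90%.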

Compound 3, a percentage reported as activity, at one concentration (the size of the read-out at that concentration, not a potency): 84%
Estimate against measurement, compound 3: 9 percentage points below; low and high end bracket the measured number.
By their numbers in this assay, from the lowest: compound 1; then compounds 2 and 3 (each within the scatter of the next).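

Adding hexyl on a saturated chain carbon gives a number 2 percentage points higher from compound 2 to compound 3 (within the scatter) in this assay, so at this far end of the chain the change is not resolved from scatter. With the chain now matched, dimethylamino in place of azetidin-1-yl on an aromatic carbon can be read alone and gives a number 16 percentage points higher from compound 1 to compound 3 (beyond the scatter). No measurement here explains either step. As far as these compounds go, how a much shorter chain such as butyl, or another amine such as pyrrolidin-1-yl on that aromatic carbon, would read remains open.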